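Aryl swap from compound 2 to compound 3

The source may hold more compounds than are shown below. What is called first, only, known or untested is meant among the compounds shown, and "the series" means these compounds.

Values in a functional assay on A549 cells (Homo sapiens) for cytotoxicity, read by MTT assay; on this read-out lower numbers stand for stronger inhibition and higher numbers for weaker inhibition:
- compound 1 `COc1cccc(-c2cc(-c3c(O)c4ccccc4oc3=O)nc(N)c2C#N)c1`: 2380 nM
- compound 2 `N#Cc1c(-c2ccc(F)cc2)cc(-c2c(O)c3ccccc3oc2=O)nc1N`: 22300 nM
- compound 3 `N#Cc1c(-c2c(F)cccc2Cl)cc(-c2c(O)c3ccccc3oc2=O)nc1N`: not yet measured

Compound 2 holds the higher of the two numbers, with compound 1 the nearest. The change to compound 3 is 2-chloro-6-fluorophenyl in place of 4-fluorophenyl on an aromatic carbon, opposite the ring nitrogen. Among the compounds with values here, one measured step bears on it, at the same place: a 9.4-fold higher number from compound 1 to compound 2 (0.97 log units; beyond the scatter). That step shows this aryl group matters in this assay, but not which way the new group goes. A move of similar or smaller size toward lower numbers is expected. The expected step is a 2.2-fold lower number from compound 2 to compound 3 (0.35 log units; beyond the scatter). The estimate for compound 3 is 10000 nM, with a range of 2500 nM to 40000 nM.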

Compound 3, half-maximal inhibitory concentration: 46300 nM
The estimate for compound 3 lay 4.6-fold (0.67 log units) below the measured number; measured number outside the range, above it.
By their numbers in this assay, from the lowest: compound 1; then compound 2; then compound 3.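

In this assay the 2-chloro-6-fluorophenyl group in place of 4-fluorophenyl gives a 2.1-fold higher number from compound 2 to compound 3 (0.32 log units; beyond the scatter) and so moves toward weaker inhibition at the position opposite the ring nitrogen. Against the 3-methoxyphenyl group the change is a 19-fold higher number from compound 1 to compound 3 (1.29 log units; beyond the scatter) and this is the widest gap among the three compounds. No supporting measurement explains this ranking. As far as these compounds go, whether the lower number of compound 1 depends on the methoxy group itself remains open. A hydroxyl or dimethylamino group on that phenyl ring would test this.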